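Swapping Trifluoromethyl for Methoxy on a Shared Core

A few compounds are considered here, and "the series" means these few. Any claim that something is new, unique, unknown or untested is made for them only; others in the source may bear on it.

Three compounds have been measured:

Compound 1, `FC(F)(F)c1ccc(-c2ccc3c(NCCCNCc4ccco4)ccnc3c2)cc1`, gives 3470 nM in an ADME assay on HepG2 cells (Homo sapiens) for cytotoxicity, read by luminescence, CellTiter-Glo and ATP content, with a stated time of 72 h; a lower number here means that less compound is needed, a higher number that more compound is needed for the effect.
Compound 2, `COc1ccc(F)cc1CNCCCNc1ccnc2cc(Cc3ccc(F)cc3Cl)ccc12`, gives 2460 nM in this assay.
Compound 3, `COc1cccc(CNCCCNc2ccnc3cc(CCC(C)C)ccc23)c1O`, gives 5390 nM in this assay.

Compound 1 holds the second highest of the three numbers; compound 2 sits a little lower and compound 3 a little higher, but both gaps lie within the usual scatter of repeated measurements, so the three are best read as roughly alike.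

Compound 4, `COc1ccc(-c2ccc3c(NCCCNCc4ccco4)ccnc3c2)cc1`, has not yet been measured. It differs from compound 1 in one place: methoxy in place of trifluoromethyl on an aromatic carbon. Among the compounds with values here, no pair of measured compounds differs in a single place, so no measured step tells what this exchange does in this assay. The three measured values cluster closely despite wide differences in their side groups, so the expectation for compound 4 is no step beyond the scatter, in either direction.

For compound 4 the expected value in this assay is 4000 nM, with a range from 1800 nM to 9000 nM, meaning an expected step of a 1.2-fold higher number from compound 1 to compound 4 (0.06 log units; within the scatter).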

Compound 4, half-maximal effective concentration: 6000 nM
For compound 4 the middle estimate is 1.5-fold (0.18 log units) below the measured one; low and high end bracket the measured number.
By their numbers in this assay, from the lowest: compounds 2, 1, 3 and 4 (each within the scatter of the next, the first and the last beyond it).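

Within the data shown here, the exchange of trifluoromethyl for methoxy on the 4-substituted phenyl group gives the first step that can be read directly, a 1.7-fold higher number from compound 1 to compound 4 (0.24 log units; within the scatter), so in this assay this change at this position does not separate the two compounds. Trifluoromethyl has no hydrogen-bond acceptor and methoxy has one, and this difference between the groups still leaves the step within the scatter. Nothing available gives a measured property that would bear on this result.

From the compounds shown here alone, it remains open whether a different group at this position, such as an amine or a carboxylic acid, would give a step beyond the scatter. This single pair also cannot show whether the same exchange would give a similar step on a compound with a different side chain.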